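Trifluoromethyl for Methyl on the Triazole Ring

The source may hold more compounds than are shown below. What is called first, only, known or untested is meant among the compounds shown, and "the series" means these compounds.

Measured compounds:
- Compound 1, `Cc1c(C(=O)Nc2ccc(Oc3ccnc4[nH]ccc34)cc2)nnn1-c1ccccc1F`: 280 nM
- Compound 2, `Cc1c(C(=O)Nc2ccc(Oc3ccnc4[nH]ccc34)cc2)nnn1-c1ccc(F)c(F)c1`: "not determined" (no result reported)

For the measured compounds named here, compound 1 is the only compound with a number in a functional assay on MCF7 cells (Homo sapiens) for cytotoxicity, read by MTT assay, with a stated time of 72 h; on this read-out lower numbers stand for stronger inhibition and higher numbers for weaker inhibition; in this assay compound 1 gives 280 nM. Compound 2 shares the same core and differs only in the fluorine pattern of the phenyl ring, but in this assay compound 2 gives "not determined" (no result reported), so it offers no comparison.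

Compound 3, `O=C(Nc1ccc(Oc2ccnc3[nH]ccc23)cc1)c1nnn(-c2ccccc2F)c1C(F)(F)F`, is the next compound to be tested. It differs from compound 1 in one place: trifluoromethyl in place of methyl on an aromatic carbon. In words, a trifluoromethyl takes the place of a methyl on an aromatic carbon of the shared core. Going by the values given here, no pair of measured compounds shows a step of this kind, so there is no measured precedent for its size or direction. Among the compounds with values here, with only the single value of compound 1 to go on, the expectation is a step from compound 1 to compound 3 of a 1.4-fold higher number from compound 1 to compound 3 (0.15 log units; within the scatter), which lies close to the usual scatter rather than clearly beyond it. Compound 3 is therefore estimated at 400 nM, within a range from 100 nM to 1600 nM.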

Compound 3, half-maximal inhibitory concentration: 290 nM
For compound 3 the middle estimate is 1.4-fold (0.14 log units) above the measured one, within the range that was stated.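

On the five-membered aromatic ring with 3 nitrogen, the carbon that holds a methyl in compound 1 can also hold a trifluoromethyl, and in this assay this exchange gives a 1.0-fold higher number from compound 1 to compound 3 (0.02 log units; within the scatter) and so leaves the two compounds indistinguishable on this read-out. For the compounds shown here, this is the first step that can be read at this position, and it shows that the cell result stays put even though the entering group counts 4 heavy atoms against 1 for the group that leaves, a finding that rests on this single pair. Nothing available here explains why the two values match.

On these data alone, whether this tolerance extends to other kinds of group remains open, since an amine, a carboxylic acid or a longer chain such as ethyl on the same carbon could behave quite differently from methyl and trifluoromethyl. Also open, as far as these compounds go, is how the fluorine pattern on the phenyl ring bears on the cell result, and whether the match between methyl and trifluoromethyl would hold with another pattern there.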